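Replacing the Dichlorophenyl on the Sulfonyl Sulfur

A few compounds are considered here, and "the series" means these few. Any claim that something is new, unique, unknown or untested is made for them only; others in the source may bear on it.

Compound 1 `O=S(=O)(C1=C(Cl)NC2SC=CN12)c1cn(C2CCNC2)c2ncccc12`: 32%
Compound 2 `CN1CCCC(n2cc(S(=O)(=O)c3cccc(F)c3)c3cccnc32)C1`: 75%
Compound 3 `CN1CCCC(n2cc(S(=O)(=O)c3cc(Cl)cc(Cl)c3)c3cccnc32)C1`: 56%

Of the compounds shown here, three have been measured in a functional assay on HeLa cells for agonist activity at 5-hydroxytryptamine receptor 6 (Homo sapiens), read by cAMP accumulation and immunoassay; a lower number here means a smaller maximal response, a higher number a larger maximal response. Compound 3 stands second highest of the three; its nearest neighbour is compound 2, whose value is higher beyond the scatter, and the furthest is compound 1, whose value is lower beyond the scatter.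

Compound 4 `CN1CCCC(n2cc(S(=O)(=O)C3=C(Cl)NC4SC=CN34)c3cccnc32)C1` is the next compound. It differs from compound 3 in one place: a group of 9 heavy atoms (5 carbon, 2 nitrogen, 1 sulfur, 1 chlorine; 2 five-membered non-aromatic rings with 2 hetero atoms each) in place of a group of 8 heavy atoms (6 carbon, 2 chlorine; one six-membered aromatic ring of carbon only), on a sulfonyl sulfur.

Among the measured compounds shown here, only one measured step also alters the group on the sulfonyl sulfur, a number 19 percentage points lower from compound 2 to compound 3 (beyond the scatter), but that step exchanges one six-membered aromatic ring for another, so it does not speak directly to the present change. Compound 1 already carries the entering group on its sulfonyl sulfur, though on a core that also differs elsewhere, and in this assay compound 1 gives 32%, clearly below compound 3. On that basis a drop is expected: a number 18 percentage points lower from compound 3 to compound 4 (beyond the scatter). For compound 4 the expected value is 38%, likely to fall between 22% and 56%.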

Compound 4, largest response reached (Emax), in percent of the reference or control that the assay uses: 68%
Compound 4: middle estimate off by 30 percentage points, on the low side, and the stated range ends below it.
By their numbers in this assay, from the lowest: compound 1; then compound 3; then compounds 4 and 2 (each within the scatter of the next).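

The 3,5-dichlorophenyl group is not needed for a strong response at this position: with the group of 2 five-membered non-aromatic rings on the sulfonyl sulfur, this assay gives a number 12 percentage points higher from compound 3 to compound 4 (beyond the scatter). A carbon-only aromatic ring is therefore not required here, and the comparison with the 3-fluorophenyl group gives a number 7 percentage points lower from compound 2 to compound 4 (within the scatter), so these two very different groups cannot be told apart in this read-out. The low value of compound 1 also gains a new reading, since holding the sulfonyl group fixed and placing 1-methylpiperidin-3-yl instead of pyrrolidin-3-yl on the aromatic nitrogen gives a number 36 percentage points higher from compound 1 to compound 4 (beyond the scatter), which shows that this second place alone can shift the maximal response by a large step.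

Nothing available explains why these changes move the response as they do. From the compounds shown here alone, it also remains open whether a plain phenyl, a pyridine ring or a small methyl group on the sulfonyl sulfur would hold the response, and whether a methyl group on the pyrrolidine nitrogen would do the same as the 1-methylpiperidin-3-yl group.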